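Swapping the aryl arm: a naphthyl analogue awaits measurement

A few compounds are considered here, and "the series" means these few. Any claim that something is new, unique, unknown or untested is made for them only; others in the source may bear on it.

Of the compounds shown here, three sharing one spiro core have been measured in an assay on membranes from brain for displacement of a labelled ligand from Sigma non-opioid intracellular receptor 1 (Cavia porcellus), read by scintillation counting, with a stated time of 120 min; on this read-out higher numbers stand for weaker inhibition and lower numbers for stronger inhibition. Compound 1 `O=C1Cc2c(csc2-c2ccc(-c3ccccc3)cc2)C2(CCN(Cc3ccccc3)CC2)O1` gives 108 nM, compound 2 `O=C1OC2(CCN(Cc3ccccc3)CC2)c2csc(-c3ccccc3)c21` gives 11 nM, and compound 3 `N#Cc1ccc(-c2scc3c2C(=O)OC32CCN(Cc3ccccc3)CC2)cc1` gives 6.3 nM. Compound 3 carries the lowest of the three numbers, yet its gap to compound 2 lies within the scatter, so those two cannot be ranked against each other; only compound 1 stands clearly apart with a higher number. Among the compounds with values here, the one step between compounds differing in a single place, a 1.7-fold lower number from compound 2 to compound 3 (0.24 log units; within the scatter), is likewise within the scatter.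

Compound 4 `O=C1OC2(CCN(Cc3ccccc3)CC2)c2csc(-c3cccc4ccccc34)c21` differs from compound 3 by naphthalen-1-yl in place of 4-cyanophenyl on an aromatic carbon. Within the data shown here, no measured step covers an exchange of the whole aryl group: the known step altered only a substituent on the phenyl, and compound 1 differs in more than one place. Because the plain phenyl of compound 2 at 11 nM and the cyanophenyl of compound 3 sit within the scatter of each other, the expected step of a 2.4-fold higher number from compound 3 to compound 4 (0.38 log units; beyond the scatter) is small and of no settled direction. Compound 4 is therefore estimated at 15 nM, within a range from 4 nM to 60 nM.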

Compound 4, inhibition constant: 5.3 nM
For compound 4 the middle estimate is 2.8-fold (0.45 log units) above the measured one; the measured number falls inside the stated range.
By their numbers in this assay, from the lowest: compounds 4, 3 and 2 (each within the scatter of the next, the first and the last beyond it); then compound 1.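

In this assay, within the data shown here, this aromatic carbon next to the ring sulfur gives the first clear step among compounds differing in one place, a 2.1-fold lower number from compound 2 to compound 4 (0.32 log units; beyond the scatter), a modest gain in binding when naphthalen-1-yl replaces phenyl. Against 4-cyanophenyl the picture differs: a 1.2-fold lower number from compound 3 to compound 4 (0.08 log units; within the scatter) leaves the two groups impossible to tell apart, and since naphthalen-1-yl carries no nitrile, a low number at this position does not depend on that group. Nothing available explains why the second aromatic ring of naphthalen-1-yl gives this step.

Open, as far as these compounds go, is whether the attachment point on the second ring matters, as naphthalen-2-yl would show, and whether any aromatic ring is needed here at all, as cyclohexyl would show. From the compounds shown here alone, it is also open how this carbon would respond to a group such as a carboxylic acid or an amine on the phenyl ring.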